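Amine-ring substituent variation and one untested compound

This account rests on a few compounds, and the source may have more. Where it says the series, first, only, none or still open, it means among the compounds named here.

Measured so far:
- compound 1 `Nc1scc(CN2CCN(c3ccc(Cl)cc3F)CC2)c1C(=O)c1ccc(Cl)cc1` gives -81% in a functional assay on CHO cells with adenosine receptor A1 (Homo sapiens) as the target, read by cAMP accumulation and immunoassay, with a stated time of 6 min, tested at 10 uM; a higher number here means a weaker effect of the compound at the concentration tested, a lower number a stronger effect
- compound 2 `Nc1scc(CN2CCN(c3ccc(OC(F)(F)F)cc3)CC2)c1C(=O)c1ccc(Cl)cc1` gives -74% in this assay
- compound 3 `Nc1scc(CN2CCN(c3cc(F)ccc3F)CC2)c1C(=O)c1ccc(Cl)cc1` gives -80% in this assay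

Compound 1 shows the lowest of the three numbers, but the steps of a number 1 percentage points higher from compound 1 to compound 3 (within the scatter) and a number 7 percentage points higher from compound 1 to compound 2 (within the scatter) both sit within the scatter, as does a number 6 percentage points lower from compound 2 to compound 3 (within the scatter), so the three compounds cannot be told apart. Compound 4 `Nc1scc(CN2CCN(CCCc3ccc(Cl)cc3)CC2)c1C(=O)c1ccc(Cl)cc1` is not yet measured; the change is 3-(4-chlorophenyl)propyl in place of 4-chloro-2-fluorophenyl on an amine nitrogen in a ring. Among the measured compounds shown here, no measured step swaps the aryl group for a chain-linked aryl; all measured steps only exchange one aryl group for another and none leaves the scatter. The step of a number 11 percentage points higher from compound 1 to compound 4 (beyond the scatter) is therefore expected to be small, with wider uncertainty than among the measured pairs. Compound 4 is estimated at -70% in this assay, within -92% to -38%.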

Compound 4, a percentage reported as activity, at one concentration (the size of the read-out at that concentration, not a potency): -76%
Compound 4: the middle estimate sits 6 percentage points above what was measured; low and high end bracket the measured number.
By their numbers in this assay, from the lowest: compounds 1, 3, 4 and 2 (each within the scatter of the next).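

On the amine nitrogen in the ring, 3-(4-chlorophenyl)propyl cannot be told apart from the directly attached aryl groups in this assay (a number 5 percentage points higher from compound 1 to compound 4 (within the scatter)) (a number 4 percentage points higher from compound 3 to compound 4 (within the scatter)) (a number 2 percentage points lower from compound 2 to compound 4 (within the scatter)). Among these four compounds, the position therefore accepts an aryl group carried on a chain as well as one attached directly, which the aryl-for-aryl steps could not show. No evidence on hand gives a reason for this result.

Open, as far as these compounds go, is whether a shorter or longer chain gives a read-out in the same range. Also open, from the compounds shown here alone, is whether a carboxylic acid or an amine at the end of the chain in place of the 4-chlorophenyl does so.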